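Swapping phenyl for a sulfonyl group on compound 2

A few compounds are considered here, and "the series" means these few. Any claim that something is new, unique, unknown or untested is made for them only; others in the source may bear on it.

Compound 1 `CC(C)=CCC/C(C)=C/CC/C(C)=C/CC[C@]1(C)CCc2c(C)c(OC(=O)NS(=O)(=O)c3ccc(C)cc3)c(C)c(C)c2O1` and compound 2 `CC(C)=CCC/C(C)=C/CC/C(C)=C/CC[C@]1(C)CCc2cc(OC(=O)Nc3ccccc3)c(C)c(C)c2O1` have both been tested in a functional assay on MDA-MB-231 cells (Homo sapiens) for antiproliferative activity, read by MTT assay, with a stated time of 96 h; on this read-out higher numbers stand for weaker inhibition and lower numbers for stronger inhibition. Compound 1 gives > 10000 nM, which is a limit of the assay and not a number. Compound 2 gives > 10000 nM, which is likewise a limit. On these data alone, compound 2 thus stands at the limit of > 10000 nM in this assay, at which 2 of the 2 values shown sit, so its true position on the scale is unknown.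

Compound 3 `CC(C)=CCC/C(C)=C/CC/C(C)=C/CC[C@]1(C)CCc2cc(OC(=O)NS(=O)(=O)c3ccc(C)cc3)c(C)c(C)c2O1` keeps the rest of compound 2 and changes one group: (4-methylphenyl)sulfonyl comes in place of phenyl on an amide-type nitrogen, next to a carbonyl carbon in the sense of being its other neighbour on that nitrogen ((4-methylphenyl)sulfonyl in place of phenyl on an amide-type nitrogen). Within the data shown here, no measured pair shows what a change of this kind does in this assay, so any forecast is uncertain. A modest gain in inhibition is expected, although the result may well stay at the same limit. The expected size of the change is an at least 1.6-fold lower number from compound 2 to compound 3 (0.22 log units; that floor lies within the scatter). For compound 3 the estimated value is 6000 nM, with an expected range from 1500 nM to 20000 nM.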

Compound 3, half-maximal inhibitory concentration: > 10000 nM
Compound 3 gave a limit, no number; the forecaster's own chance of this, stated with the estimate: 45%; at least 1.6-fold (0.22 log units) between middle value and limit.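

In this assay compound 3 gives a limit and no number, as do compound 1 and compound 2, so no step among these compounds can be read: the limit of > 10000 nM in this assay, at which 3 of the 3 values shown sit.

The compounds shown leave open whether (4-methylphenyl)sulfonyl in place of phenyl, or hydrogen in place of methyl, changes inhibition at all, and where each compound truly stands on the scale.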